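The source may hold more compounds than are shown below. What is called first, only, known or untested is meant among the compounds shown, and "the series" means these compounds.

Measured compounds:
compound 1, `C=Cc1ccc(S(=O)(=O)Nc2ccc3oc(-c4ccccc4)nc3c2)cc1` — in an assay on cells for inhibition of HSP60/HSP10 (Homo sapiens), with a stated time of 60 min (a lower number here means a stronger inhibitor, a higher number a weaker inhibitor), compound 1 reports only a limit, > 100000 nM.
compound 2, `O=S(=O)(Nc1ccc2oc(-c3ccccc3)nc2c1)c1ccccc1Cl` — in this assay compound 2 likewise reports only a limit, > 100000 nM.

Compound 2 thus stands at a limit of this assay and not at a number. For the measured compounds named here, the one measured step, a step that the two limits leave unreadable from compound 1 to compound 2, has no readable size because of the limit of > 100000 nM in this assay, at which 2 of the 2 values shown sit, so the series so far gives no step of known size at all.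

Compound 3 is `O=S(=O)(Nc1ccc2oc(-c3ccccc3)nc2c1)c1ccc(Cl)s1`. Against compound 2 the change is 5-chlorothiophen-2-yl in place of 2-chlorophenyl on a sulfonyl sulfur. Going by the values given here, the only measured step that bears on it is a step that the two limits leave unreadable from compound 1 to compound 2, and it is unreadable; both measured values sit at the same limit, (the limit of > 100000 nM in this assay, at which 2 of the 2 values shown sit). There is therefore no basis on the numbers shown to expect a step beyond the scatter in either direction, and the most likely outcome is that compound 3 also returns only a limit.

Compound 3 is estimated at 150000 nM, with a range from 40000 nM to 600000 nM. This estimate means an expected step that the limit leaves unreadable from compound 2 to compound 3, that is, essentially no movement from the limit.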

Compound 3, half-maximal inhibitory concentration: 70000 nM
Compound 3: middle estimate off by 2.1-fold (0.33 log units), on the high side; measured number inside the range.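

For the compounds shown here, at the position on a sulfonyl sulfur whose other neighbour is the sulfonamide nitrogen, compound 3 with 5-chlorothiophen-2-yl is the only one of the three compounds to give a number in this assay, namely 70000 nM. Compound 2 with 2-chlorophenyl and compound 1 with 4-vinylphenyl give only limits. Replacing 2-chlorophenyl gives an at least 1.4-fold lower number from compound 2 to compound 3 (0.15 log units; that floor lies within the scatter) and replacing 4-vinylphenyl gives an at least 1.4-fold lower number from compound 1 to compound 3 (0.15 log units; that floor lies within the scatter), so neither change can yet be called a gain beyond the scatter. Both steps remain floors and not sizes because the partner of compound 3 in each pair rests on a limit: the limit of > 100000 nM in this assay, at which 2 of the 3 values shown sit.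

The compounds shown leave open whether the readable value goes with the thiophene ring or with its chlorine, as neither thiophen-2-yl without chlorine nor 5-methylthiophen-2-yl is among them. Also open, as far as these compounds go, is how an amine or a carboxylic acid on that ring would read in this assay, and whether any group at this position can give a value beyond the scatter of compound 3.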